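The source may hold more compounds than are shown below. What is called first, only, known or untested is meant among the compounds shown, and "the series" means these compounds.

Going by the values given here, in a functional assay on MM1.S cells (Homo sapiens) for cytotoxicity, read by MTT assay, with a stated time of 48 h (on this read-out lower numbers stand for stronger inhibition and higher numbers for weaker inhibition), compound 1 `O=C(c1ccccc1)N(N=C1C(Cl)=C(Cl)C(Cl)=C1Cl)C(=O)c1ccccc1` gives 2000 nM, the only actual number among the compounds tested so far. For compound 2 `COC1(OC)C(Cl)=C(Cl)C(Cl)=C1Cl` the entry is "not determined" (no result reported). Compound 3 `CC(C)(C)NN=C1C(Cl)=C(Cl)C(Cl)=C1Cl` is reported only as a limit, > 3000 nM. Compound 4 `O=C(NN=C1C(Cl)=C(Cl)C(Cl)=C1Cl)c1ccccc1` has yet to be measured in this assay. Its structure departs from that of compound 1 in one place: hydrogen in place of benzoyl on an amide-type nitrogen. Among the compounds with values here, no measured pair shows this change directly, so the expectation is anchored on compound 1 at 2000 nM. The expected step is a 1.3-fold higher number from compound 1 to compound 4 (0.10 log units; within the scatter), leaning slightly weaker but not beyond the scatter. For compound 4 the estimated value is 2500 nM, with an expected range from 900 nM to 7000 nM.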

Compound 4, half-maximal inhibitory concentration: 800 nM
Beside the measured number, compound 4's estimate is 3.1-fold (0.49 log units) above it, outside the stated range (below it).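

Hydrogen in place of benzoyl on an amide-type nitrogen gives a 2.5-fold lower number from compound 1 to compound 4 (0.40 log units; beyond the scatter) in this assay. Going by these compounds alone, this is the first direct reading at this position, and it shows that the benzoyl that leaves is not needed for cytotoxicity in these cells, since the compound with hydrogen there gives the lower number. Nothing shown accounts for this gain. The compounds shown leave open whether an acetyl or a methyl on this nitrogen would keep the lower number. They also leave open whether a methoxy or an amine on the phenyl ring of the remaining benzoyl would shift it.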